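A few compounds are considered here, and "the series" means these few. Any claim that something is new, unique, unknown or untested is made for them only; others in the source may bear on it.

In a functional assay on HL60/MX2 cells (Homo sapiens) for antiproliferative activity, read by MTT assay, with a stated time of 48 h (on this read-out lower numbers stand for stronger inhibition and higher numbers for weaker inhibition), the measured compounds are:

- Compound 1 `Cn1c(N)c(-c2nc3ccccc3[nH]2)c2nc(C#N)c(C#N)nc21`: > 50000 nM (a limit)
- Compound 2 `CCn1c(N)c(-c2nc3ccccc3[nH]2)c2nc(C#N)c(C#N)nc21`: > 50000 nM (a limit)

Compound 2 gives > 50000 nM, which is a limit of the assay and not a number. Among the measured compounds shown here, it therefore has no exact place on the scale, and the only other value shown is also a limit, as the limit of > 50000 nM in this assay, at which 2 of the 2 values shown sit, records.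

The next compound, compound 3 `CN(C)CCn1c(N)c(-c2nc3ccccc3[nH]2)c2nc(C#N)c(C#N)nc21`, keeps the shared core and changes the ethyl to 2-(dimethylamino)ethyl: dimethylamino in place of hydrogen on a saturated chain carbon, two bonds along the chain from an aromatic nitrogen.

For the measured compounds named here, only one measured step bears on this change, a step that the two limits leave unreadable from compound 1 to compound 2. It involves a methyl in place of hydrogen, not a dimethylamino group, and it has no readable size to carry over. Any expectation in this assay is therefore weak. A modest move toward stronger inhibition is expected, though compound 3 may well report only a limit too.

The expected step is an at least 1.6-fold lower number from compound 2 to compound 3 (0.22 log units; that floor lies within the scatter). For compound 3 the estimated value is 30000 nM, with an expected range from 6000 nM to 100000 nM.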

Compound 3, half-maximal inhibitory concentration: 3780 nM
The estimate for compound 3 lay 7.9-fold (0.90 log units) above the measured number; measured number outside the range, below it.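

In this assay, among the compounds shown here, the chain on the aromatic nitrogen produces a readable difference for the first time. Dimethylamino in place of hydrogen on a saturated chain carbon, two bonds along the chain from an aromatic nitrogen, gives an at least 13-fold lower number from compound 2 to compound 3 (1.12 log units; beyond the scatter), and the same change counted from the methyl compound, (dimethylamino)methyl in place of hydrogen on a saturated chain carbon bound to an aromatic nitrogen, gives an at least 13-fold lower number from compound 1 to compound 3 (1.12 log units; beyond the scatter). Both steps are floors and not exact sizes, because each starts from a compound that carries a limit and not a number: the limit of > 50000 nM in this assay, at which 2 of the 3 values shown sit.

As far as these compounds go, what remains open is whether the step belongs to the dimethylamino group itself or would also follow from another group at the end of the same chain, a question that a primary amine, a morpholine, a hydroxyl or a longer chain ending in dimethylamino could address. Also open, from the compounds shown here alone, is how far the length of the chain matters, and whether this step would look the same on any other cell line.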